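Halogen Swap on the Benzoyl Hydrazide Arm of Compound 3

A few compounds are considered here, and "the series" means these few. Any claim that something is new, unique, unknown or untested is made for them only; others in the source may bear on it.

Compound 1, `O=C(N/N=C/c1c(-c2cc3ccc(Br)cc3oc2=O)[nH]c2ccccc12)c1ccccc1`: in a toxicity assay on Vero cells (Chlorocebus sabaeus) for inhibition, read by MTT assay, with a stated time of 48 h (a lower number here means a stronger inhibitor, a higher number a weaker inhibitor), compound 1 gives > 200000 nM, a limit of the assay.
Compound 2, `O=C(N/N=C/c1c(-c2cc3ccc(Br)cc3oc2=O)[nH]c2ccccc12)c1ccc(Cl)cc1`: in this assay compound 2 gives 71400 nM.
Compound 3, `O=C(N/N=C/c1c(-c2cc3ccc(Br)cc3oc2=O)[nH]c2ccccc12)c1ccccc1F`: in this assay compound 3 gives > 200000 nM, a limit of the assay.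

Compound 3 stands at the upper edge of what is shown, namely (the limit of > 200000 nM in this assay, at which 2 of the 3 values shown sit). Compound 4, `O=C(N/N=C/c1c(-c2cc3ccc(Br)cc3oc2=O)[nH]c2ccccc12)c1cccc(Br)c1`, differs from compound 3 in one place: 3-bromophenyl in place of 2-fluorophenyl on a carbonyl carbon. Among the compounds with values here, two measured steps bear on this change. The step of an at least 2.8-fold lower number from compound 1 to compound 2 (0.44 log units; beyond the scatter) shows that a halogen on the phenyl can bring the number down from the limit. The step of an at least 2.8-fold higher number from compound 2 to compound 3 (0.44 log units; beyond the scatter) shows that a different halogenated phenyl returns the number to the limit, and a step that the two limits leave unreadable from compound 1 to compound 3. A 3-bromophenyl on the same carbonyl carbon is therefore expected to land somewhere between these outcomes. Compound 4 is expected to move by an at least 1.5-fold lower number from compound 3 to compound 4 (0.18 log units; that floor lies within the scatter). Compound 4 is estimated at 130000 nM, between 50000 nM and 200000 nM.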

Compound 4, half-maximal inhibitory concentration: > 200000 nM
Compound 4: no number, only a limit (the forecaster's own chance of this, stated with the estimate: 45%); middle value at least 1.5-fold (0.18 log units) away from the limit.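

In this assay compound 4 gives > 200000 nM, a limit of the assay. The 3-bromophenyl on the carbonyl carbon gives an at least 2.8-fold higher number from compound 2 to compound 4 (0.44 log units; beyond the scatter), so a halogen on this phenyl does not by itself bring the number down. The steps to compound 4 from compound 1 and from compound 3 cannot be read, and the set now stands thus: the limit of > 200000 nM in this assay, at which 3 of the 4 values shown sit.

The compounds shown leave open whether the lower number of compound 2 follows from the chloro group itself or from where it sits on the phenyl. They also leave open what an amine or a carboxylic acid on this phenyl would give in this assay.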